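From 3-Bromophenyl to 2,4-Dimethylphenyl on the Amide

This account rests on a few compounds, and the source may have more. Where it says the series, first, only, none or still open, it means among the compounds named here.

For the measured compounds named here, in a functional assay on MDA-MB-231 cells (Homo sapiens) for cytotoxicity, read by MTT assay, with a stated time of 72 h (a higher number here means a weaker inhibitor, a lower number a stronger inhibitor), compound 1 `O=C(CN1CCN(c2nnc(Cc3ccccc3)c3ccccc23)CC1)Nc1ccc(F)c(F)c1` gives 2750 nM and compound 2 `O=C(CN1CCN(c2nnc(Cc3ccccc3)c3ccccc23)CC1)Nc1cccc(Br)c1` gives 3880 nM, so compound 2 stands within the scatter of the only other measured number. Compound 3 `Cc1ccc(NC(=O)CN2CCN(c3nnc(Cc4ccccc4)c4ccccc34)CC2)c(C)c1` carries 2,4-dimethylphenyl in place of 3-bromophenyl on an amide-type nitrogen. Going by the values given here, the one measured step at this place is a 1.4-fold higher number from compound 1 to compound 2 (0.15 log units; within the scatter), so no step beyond the scatter is expected in this assay. The estimated step is a 1.1-fold lower number from compound 2 to compound 3 (0.04 log units; within the scatter). Compound 3 is expected to give 3500 nM, with an estimated range of 1500 nM to 8000 nM.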

Compound 3, half-maximal inhibitory concentration: 181000 nM
Estimate against measurement, compound 3: 52-fold (1.71 log units) below; the whole stated range lies below it.
By their numbers in this assay, from the lowest: compounds 1 and 2 (each within the scatter of the next); then compound 3.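

In this assay the group on this amide-type nitrogen turns out not to be interchangeable: 2,4-dimethylphenyl gives a 47-fold higher number from compound 2 to compound 3 (1.67 log units; beyond the scatter) and also a 66-fold higher number from compound 1 to compound 3 (1.82 log units; beyond the scatter). The earlier change between compounds 1 and 2 stayed within the scatter, so a swap of aryl groups here can do nothing measurable or can cost a great deal of activity. Nothing available explains this loss. Whether both methyl groups are needed for the loss remains open, since a phenyl ring with a single methyl group is not among the compounds shown. From the compounds shown here alone, how a pyridine ring or a carboxylic acid on the ring would read here also remains open.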